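The compounds below may be only part of what the source reports. "The series", "measured", "known", "first", "only" and "open" are said of these compounds alone.

Compound 1 `O=C(/C=C/c1ccc(/C=N/NC(=O)c2ccncc2)cc1)c1cccc(Br)c1` gives the lowest number of the three measured compounds in a functional assay on the whole organism (Ear) for inhibition, with Mus musculus as the target, with a stated time of 30 min, at a dose of 100 mg/kg by the intraperitoneal route (a lower number here means less inhibition, a higher number more inhibition at the dose given (going by the name of the read-out)), where compound 1 gives 14%. For the measured compounds named here, compound 2 `N=C(N)N/N=C/c1ccc(/C=C/C(=O)c2ccc(Cl)cc2Cl)cc1` gives 92.5%, and compound 3 `N=C(N)N/N=C/c1ccc(/C=C/C(=O)c2ccccc2Cl)cc1` gives 84.1%; the only single-point step, a number 8.4 percentage points lower from compound 2 to compound 3 (within the scatter), concerns a chloro removed from the shared core and lies within the scatter. Compound 4 `O=C(N/N=C/c1ccc(/C=C/C(=O)c2ccccc2Br)cc1)c1ccncc1` differs from compound 1 by 2-bromophenyl in place of 3-bromophenyl on a carbonyl carbon. Going by the values given here, no measured step moves a bromine between positions on that ring, so nothing directly bears on the change, and the step of a number 11 percentage points higher from compound 1 to compound 4 (beyond the scatter) is only an expectation of a small rise with wide uncertainty. Compound 4 is therefore estimated at 25%, with a range from 5% to 60%.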

Compound 4, a percentage reported as inhibition, in the whole organism at one dose (the size of the read-out at that dose, not a potency): 48.7%
Compound 4: the middle estimate sits 23.7 percentage points below what was measured, and the stated range covers the measured number.
By their numbers in this assay, from the lowest: compound 1; then compound 4; then compounds 3 and 2 (each within the scatter of the next).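

In this assay, 2-bromophenyl in place of 3-bromophenyl on a carbonyl carbon brings a number 34.7 percentage points higher from compound 1 to compound 4 (beyond the scatter), so the same atoms, joined differently, change the read-out. Unlike the earlier chloro step, which stayed within the scatter, this step shows that the read-out at this position depends on where the bromine stands on the ring. Nothing available explains this difference.

The compounds shown leave open how a methoxy group or an amine on this ring would read. They also leave open whether a step of this size would recur with chloro in place of bromine.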